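The source may report more compounds than this note shows. Statements on the series, on what has been measured and on what is new or still open speak of the compounds shown alone.

Measured in a functional assay on Jurkat cells (Homo sapiens) for cytotoxicity, read by MTT assay, with a stated time of 24 h; on this read-out higher numbers stand for an effect only at larger amounts of compound and lower numbers for an effect already at smaller amounts:
- compound 1 `CCCCC#Cc1cc(C(=O)OCC)nc2ccc(OC)cc12`: 15900 nM
- compound 2 `CCOC(=O)c1cc(C#Cc2ccc(N)cc2)c2cc(OC)ccc2n1`: 61000 nM

Of these two numbers, compound 1 has the lowest, 15900 nM, and so responds at the smaller amount in this assay. Compound 3 `CCOC(=O)c1cc([Se]c2ccccc2C)c2cc(OC)ccc2n1` departs from it at one place: a group of 8 heavy atoms (7 carbon, 1 selenium; one six-membered aromatic ring of carbon only) in place of a group of 6 heavy atoms (6 carbon; no ring), on an aromatic carbon. The hex-1-yn-1-yl group leaves an aromatic carbon opposite the ring nitrogen. Among the compounds with values here, only one measured step bears on this: a 3.8-fold higher number from compound 1 to compound 2 (0.58 log units; beyond the scatter). That step also brings in a six-membered aromatic ring, but it keeps the triple bond. Within the data shown here, no measured step shows what replacing the triple bond with selenium does, so the guide is weak. Among the measured compounds shown here, a modest move towards a higher number is expected, no larger than that step, with a wide margin in either direction. The expected change is a 1.6-fold higher number from compound 1 to compound 3 (0.20 log units; within the scatter). For compound 3 the estimated value is 25000 nM, with an expected range of 7000 nM to 80000 nM.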

Compound 3, half-maximal effective concentration: 14900 nM
Compound 3: the middle estimate sits 1.7-fold (0.22 log units) above what was measured; measured number inside the range.
By their numbers in this assay, from the lowest: compounds 3 and 1 (each within the scatter of the next); then compound 2.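

In this assay, the aromatic carbon opposite the ring nitrogen accepts two very different groups with no change beyond the scatter: a 1.1-fold lower number from compound 1 to compound 3 (0.03 log units; within the scatter). The triple bond of the hex-1-yn-1-yl group is therefore not needed for a number of this size, and a six-membered aromatic ring of carbon only does not by itself bring a higher number, so the rise in a 3.8-fold higher number from compound 1 to compound 2 (0.58 log units; beyond the scatter) cannot be read as an effect of the ring alone. No measurement shown explains why the groups of compound 1 and compound 3 read alike.

Whether selenium matters remains open, as the compounds shown include no sulfur or oxygen atom in its place. Also open, from the compounds shown here alone, are the effect of the methyl group on the new ring and of a carboxylic acid in place of the ethoxycarbonyl group.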